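Switching the Aniline Substituent of a Styryl Sulfone

The source may report more compounds than this note shows. Statements on the series, on what has been measured and on what is new or still open speak of the compounds shown alone.

Compound 1: `COc1ccc(OC)c(/C=C/S(=O)(=O)Cc2ccc(OC)c(N)c2)c1` gives 750 nM
Compound 2: `COc1cc(OC)c(/C=C/[S+]([O-])Cc2ccc(OC)c(N)c2)c(OC)c1` gives 20 nM
Compound 3: `COC(=O)[C@H](C)Nc1cc(CS(=O)(=O)/C=C/c2c(OC)cc(OC)cc2OC)ccc1OC` gives 200 nM

These three values come from a functional assay on K562 cells (Homo sapiens) for cytotoxicity, read by trypan blue exclusion, with a stated time of 96 h; on this read-out lower numbers stand for stronger inhibition and higher numbers for weaker inhibition. Compound 3 holds the second highest of the three numbers. Its nearest neighbour is compound 1, whose value lies beyond the scatter above it, and its furthest is compound 2, whose value lies beyond the scatter below it. So compound 3 sits between the two, closer to the weaker compound 1 than to the stronger compound 2.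

Compound 4, `COc1cc(OC)c(/C=C/S(=O)(=O)Cc2ccc(OC)c(NC(C(=O)O)c3ccc(F)cc3)c2)c(OC)c1`, has not yet been measured in this assay. It differs from compound 3 in a single place: carboxy(4-fluorophenyl)methyl in place of 1-(methoxycarbonyl)ethyl on a nitrogen on an aromatic ring. The group that leaves carries no hydrogen-bond donor, while the group that enters brings one and a six-membered aromatic ring.

Among the compounds with values here, no pair among the measured compounds shows a comparable change, so nothing in the data fixes the size of this step. The step that is expected is a 1.5-fold higher number from compound 3 to compound 4 (0.18 log units; within the scatter), a small shift towards a somewhat higher number. Compound 4 is therefore estimated at 300 nM, with a range from 80 nM to 1200 nM.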

Compound 4, half-maximal inhibitory concentration: 80 nM
Beside the measured number, compound 4's estimate is 3.8-fold (0.57 log units) above it, and the stated range covers the measured number.
By their numbers in this assay, from the lowest: compound 2; then compound 4; then compound 3; then compound 1.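

Within the data shown here, on the nitrogen on an aromatic ring, carboxy(4-fluorophenyl)methyl in place of 1-(methoxycarbonyl)ethyl gives a 2.5-fold lower number from compound 3 to compound 4 (0.40 log units; beyond the scatter) in this assay and is the first single-place change that can be read at this position. The position therefore accepts a larger substituent, with 11 heavy atoms instead of 6 and a six-membered aromatic ring, and the number still falls rather than rises. Nothing measured here explains why the number fell.

The change alters several features at once, so this one pair cannot show whether the step follows the carboxylic acid, the 4-fluorophenyl ring or the loss of the defined stereocentre. Also open, from the compounds shown here alone, is how a simple phenyl ring, a methyl ester of compound 4, or a longer alkyl chain on this nitrogen would read.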